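Trifluoromethyl in Place of Fluoro on the Aryl Ring

This account rests on a few compounds, and the source may have more. Where it says the series, first, only, none or still open, it means among the compounds named here.

The compounds share one core and differ only in the group on the outer aromatic ring. Compound 1, `CC1(C)Oc2ccc(C#N)cc2[C@@H](/N=C(\NC#N)Nc2ccccc2)[C@@H]1O`, carries the bare ring; in a functional assay (aorta) for inhibition, with Rattus norvegicus as the target (a higher number here means a weaker inhibitor, a lower number a stronger inhibitor), compound 1 gives 1400 nM; 4200 nM; 1300 nM (3 entries), several readings that scatter around each other (the several entries of compound 1 in this assay, 1400 nM; 4200 nM; 1300 nM (3 entries)). Compound 2, `CC1(C)Oc2ccc(C#N)cc2[C@@H](/N=C(\NC#N)Nc2ccc(O)cc2)[C@@H]1O`, carries hydroxy and gives 2200 nM. Compound 3, `CC1(C)Oc2ccc(C#N)cc2[C@@H](/N=C(\NC#N)Nc2ccc(F)cc2)[C@@H]1O`, carries fluoro and gives 1400 nM, the smaller of the two single numbers, yet the step of a 1.6-fold lower number from compound 2 to compound 3 (0.20 log units; within the scatter) is within the scatter, so compound 2 and compound 3 cannot be told apart, and the readings of compound 1 lie in the same region. Compound 4, `CC1(C)Oc2ccc(C#N)cc2[C@@H](/N=C(\NC#N)Nc2ccc(C(F)(F)F)cc2)[C@@H]1O`, is not yet measured. It differs from compound 3 by trifluoromethyl in place of fluoro on an aromatic carbon, in words trifluoromethyl in place of fluoro on an aromatic carbon. Among the measured compounds shown here, the one measured step of this kind, hydroxy to fluoro, was too small to count, and the bare ring gave similar numbers, so the change of the outer group has so far left this assay almost untouched. No shift beyond the scatter is therefore expected, and the estimated step is a 1.1-fold lower number from compound 3 to compound 4 (0.03 log units; within the scatter). Compound 4 is expected to give about 1300 nM, between 450 nM and 4000 nM.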

Compound 4, half-maximal inhibitory concentration: 8100 nM
Compound 4: middle estimate off by 6.2-fold (0.79 log units), on the low side; measured number above the stated range.
By their numbers in this assay, from the lowest: compounds 3 and 2 (each within the scatter of the next); then compound 4.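

In this assay, among the compounds shown here, the outer group at this position does matter: trifluoromethyl in place of fluoro gives a 5.8-fold higher number from compound 3 to compound 4 (0.76 log units; beyond the scatter), the first change of this group with a step beyond the scatter. Trifluoromethyl in place of hydroxy points the same way, with a 3.7-fold higher number from compound 2 to compound 4 (0.57 log units; beyond the scatter), so compound 4 is a weaker inhibitor than either compound 2 or compound 3, and the earlier impression of a position indifferent to its group holds only for the smaller set of hydroxy, fluoro and the bare ring. The printed number of compound 4, 8100 nM, also lies above every reading of the bare ring, though those readings spread widely themselves: the several entries of compound 1 in this assay, 1400 nM; 4200 nM; 1300 nM (3 entries)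

The compounds shown cannot say what about trifluoromethyl produces this loss, since it differs from fluoro in more than one respect and it is the only group of its kind here. A methyl group, a chlorine atom or a methoxy group at the same place would help to separate these possibilities, and an amine or a carboxylic acid there would show how far the tolerance of this position extends.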